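Replacing the aryl ether arm of compound 1 with a butyl chain

A few compounds are considered here, and "the series" means these few. Any claim that something is new, unique, unknown or untested is made for them only; others in the source may bear on it.

Measured compounds and their values:
compound 1 `COc1ccc(COCNc2n[n+]([O-])c3ccccc3[n+]2[O-])cc1` gives 1150 nM
compound 2 `CCOCNc1n[n+]([O-])c2ccccc2[n+]1[O-]` gives 4230 nM
compound 3 `CC(C)CCOCNc1n[n+]([O-])c2ccccc2[n+]1[O-]` gives 2860 nM

The three compounds share one core and differ only in the group on a saturated chain carbon bound to an oxygen on a saturated carbon. In a functional assay on SMMC-7721 cells (Homo sapiens) for cytotoxicity, read by MTT assay, with a stated time of 72 h (a higher number here means a weaker inhibitor, a lower number a stronger inhibitor), compound 1 stands lowest of the three numbers; its nearest neighbour is compound 3 and its furthest is compound 2.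

Compound 4 `CCCCCOCNc1n[n+]([O-])c2ccccc2[n+]1[O-]` has not yet been measured. It differs from compound 1 as follows: butyl in place of 4-methoxyphenyl on a saturated chain carbon bound to an oxygen on a saturated carbon.

Among the compounds with values here, two measured steps bear on this change. The step of a 3.7-fold higher number from compound 1 to compound 2 (0.57 log units; beyond the scatter) swaps the 4-methoxyphenyl for the smallest chain, and the step of a 2.5-fold higher number from compound 1 to compound 3 (0.40 log units; beyond the scatter) swaps it for isobutyl; both go the same way and both lie beyond the scatter. The step of a 1.5-fold lower number from compound 2 to compound 3 (0.17 log units; within the scatter) is within the scatter, so lengthening the chain itself barely moves the number. Butyl resembles isobutyl in size, so a step of similar magnitude is expected in this assay, toward a higher number.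

For compound 4 the expected value in this assay is therefore 3000 nM, with a range of 1500 nM to 6000 nM. This amounts to an expected step of a 2.6-fold higher number from compound 1 to compound 4 (0.42 log units; beyond the scatter), because it echoes a 2.5-fold higher number from compound 1 to compound 3 (0.40 log units; beyond the scatter).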

Compound 4, half-maximal inhibitory concentration: 3050 nM
Compound 4: middle estimate off by 1.0-fold (0.01 log units), on the low side; low and high end bracket the measured number.
By their numbers in this assay, from the lowest: compound 1; then compounds 3, 4 and 2 (each within the scatter of the next).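

Against the 4-methoxyphenyl arm, butyl gives a 2.7-fold higher number from compound 1 to compound 4 (0.42 log units; beyond the scatter) in this assay, so a third saturated chain at this place, on a saturated chain carbon bound to an oxygen on a saturated carbon, stands apart from compound 1 by more than the scatter. The new compound also adds a straight chain to the comparison, and it separates neither from the branched arm, with a 1.1-fold higher number from compound 3 to compound 4 (0.03 log units; within the scatter), nor from the shortest arm, with a 1.4-fold lower number from compound 2 to compound 4 (0.14 log units; within the scatter); across the three compounds with saturated chains, neither branching nor length can be seen to matter, and only the presence of the 4-methoxyphenyl group goes with a distinct number. No independent measurement is available to explain why compound 1 gives the lowest number of the four.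

The ring and its methoxy group leave together in each of these steps, so a plain phenyl arm would be needed to tell their shares apart. From the compounds shown here alone, whether a much longer chain, or a chain ending in an amine or a carboxylic acid, would shift the number at this place also remains open.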